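Chain lengthening on the saturated ring carbon of the tosyl series

This account rests on a few compounds, and the source may have more. Where it says the series, first, only, none or still open, it means among the compounds named here.

Compound 1 `Cc1ccc(S(=O)(=O)N2CC[C@@H](Cl)C[C@@H]2CC(C)C)cc1` and compound 2 `CCCCCCC[C@H]1C[C@H](Cl)CCN1S(=O)(=O)c1ccc(C)cc1` share a core; compound 3 `Cc1ccc(S(=O)(=O)N2CCC(Br)=CC2CC(C)C)cc1` and compound 4 `CCCCCCCC1C=C(Br)CCN1S(=O)(=O)c1ccc(C)cc1` share another, and the difference between the two cores is not broken down here. In a functional assay on SW1573 cells (Homo sapiens) for antiproliferative activity, read by sulforhodamine B assay, with a stated time of 48 h (a lower number here means a stronger inhibitor of growth, a higher number a weaker inhibitor of growth), compound 1 gives 19000 nM. Compound 2 reaches only the limit of this assay, > 100000 nM (the limit of > 100000 nM in this assay, at which 1 of the 3 values shown sits). The change hexyl in place of isopropyl on a saturated chain carbon bound to a saturated ring carbon gives an at least 5.2-fold higher number from compound 1 to compound 2 (0.72 log units; beyond the scatter). In this assay compound 3 gives 26000 nM, within the scatter of compound 1. Compound 4 carries the same change, (hexyl in place of isopropyl on a saturated chain carbon bound to a saturated ring carbon), on its own core. By analogy with an at least 5.2-fold higher number from compound 1 to compound 2 (0.72 log units; beyond the scatter), the corresponding step is expected to be a 5.4-fold higher number from compound 3 to compound 4 (0.73 log units; beyond the scatter). Compound 4 is therefore expected near 140000 nM. For compound 4 the expected span runs from 60000 nM to 400000 nM, with a limit reading likely.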

Compound 4, concentration for 50% growth inhibition: 49000 nM
Compound 4: middle estimate off by 2.9-fold (0.46 log units), on the high side; measured number outside the range, below it.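

In this assay, hexyl in place of isopropyl gives a 1.9-fold higher number from compound 3 to compound 4 (0.28 log units; within the scatter), so on the core of compound 3 the change cannot be told from the scatter. The change does not carry over in size between the two cores: the same change on two cores in this assay, an at least 5.2-fold higher number (0.72 log units; beyond the scatter) from compound 1 to compound 2 and a 1.9-fold higher number (0.28 log units; within the scatter) from compound 3 to compound 4, at least 2.7-fold (0.44 log units) apart, beyond the scatter of two such steps. Among these compounds, the earlier step ends on a limit, for compound 2, and only two pairs stand here, so neither an exact size for that step nor a rule for other cores can be read: the limit of > 100000 nM in this assay, at which 1 of the 4 values shown sits.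

Open, on these data alone, is whether a longer chain, or an amine on the chain, would behave alike on both cores. As far as these compounds go, the two cores differ in more than one place, and which of those differences goes with the gap between the steps also stays open.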